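The source may report more compounds than this note shows. Statements on the series, on what has been measured and on what is new or still open speak of the compounds shown alone.

Measured in a functional assay on NCI-H1581 cells (Homo sapiens) for antiproliferative activity, read by CCK-8 assay, with a stated time of 72 h; on this read-out higher numbers stand for weaker inhibition and lower numbers for stronger inhibition:

- compound 1 `COc1cc(OC)c(Cl)c(-c2ccc3c(NC(=O)c4ccc(N5CCCCC5)cc4)n[nH]c3n2)c1Cl`: 558 nM
- compound 2 `COc1cc(OC)c(Cl)c(-c2ccc3c(NC(=O)c4ccc(N5CCN(C(C)C)CC5)cc4)n[nH]c3n2)c1Cl`: 1.4 nM

Of the two, compound 2 stands lowest, at 1.4 nM. Compound 3 `COc1cc(OC)c(Cl)c(-c2ccc3c(NC(=O)c4ccc(N5CCN(S(C)(=O)=O)CC5)cc4)n[nH]c3n2)c1Cl` differs from it as follows: methylsulfonyl in place of isopropyl on an amine nitrogen in a ring. Among the measured compounds shown here, no measured step covers this exact change. The nearest is a 400-fold lower number from compound 1 to compound 2 (2.60 log units; beyond the scatter), a large step with 4-isopropylpiperazin-1-yl in place of piperidin-1-yl on an aromatic carbon. Since that step touched the same group, a clear move to a higher number, weaker inhibition, is expected, though only part of the way back. The expected change is a 21-fold higher number from compound 2 to compound 3 (1.33 log units; beyond the scatter). For compound 3 the estimated value is 30 nM, with a range of 4 nM to 250 nM.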

Compound 3, half-maximal inhibitory concentration: 245 nM
Beside the measured number, compound 3's estimate is 8.2-fold (0.91 log units) below it; low and high end bracket the measured number.
By their numbers in this assay, from the lowest: compound 2; then compound 3; then compound 1.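

In this assay the substituent on the amine nitrogen in the ring proves decisive, since methylsulfonyl in place of isopropyl gives a 180-fold higher number from compound 2 to compound 3 (2.24 log units; beyond the scatter). Set against piperidin-1-yl, 4-(methylsulfonyl)piperazin-1-yl gives only a 2.3-fold lower number from compound 1 to compound 3 (0.36 log units; beyond the scatter), so the second ring nitrogen does not by itself bring the large gain seen with 4-isopropylpiperazin-1-yl. No evidence at hand explains this difference. On these data alone, what remains open is whether a methyl, an acetyl or a longer alkyl chain on that nitrogen would keep the number near that of compound 2.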